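The source may report more compounds than this note shows. Statements on the series, on what has been measured and on what is new or still open speak of the compounds shown alone.

Measured compounds, growth inhibition in a functional assay on MCF7 cells (Homo sapiens) for inhibition, read by sulforhodamine B assay, with a stated time of 24 h; a higher number here means a weaker inhibitor of growth, a lower number a stronger inhibitor of growth:
compound 1 `CC1=C(C(=O)Nc2ccc(C)cc2)C(c2cn(-c3ccccc3)nc2-c2ccccc2)NC(=S)N1` gives 56100 nM
compound 2 `COc1ccc(NC(=O)C2=C(C)NC(=S)NC2c2cn(-c3ccccc3)nc2-c2ccccc2)cc1` gives 77300 nM
compound 3 `CC1=C(C(=O)Nc2ccc(C)cc2)C(c2cn(-c3ccccc3)nc2-c2ccc(Cl)cc2)NC(=O)N1` gives 69700 nM

All three numbers lie within the scatter of one another, so no order among them can be drawn. Compound 4 `COc1ccc(NC(=O)C2=C(C)NC(=O)NC2c2cn(-c3ccccc3)nc2-c2ccc(Cl)cc2)cc1` is not yet measured in this assay.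

One change is made twice in the series. From compound 1 to compound 2 it is methoxy in place of methyl on an aromatic carbon, and that step in this assay is a 1.4-fold higher number from compound 1 to compound 2 (0.14 log units; within the scatter). From compound 3 to compound 4 the change is methoxy in place of methyl on an aromatic carbon, at the same place word for word, so this is the same change. The two cores, that of compound 1 and that of compound 3, differ in more than one place; the difference between them is not broken down here.

Given that the earlier step was a 1.4-fold higher number from compound 1 to compound 2 (0.14 log units; within the scatter), compound 4 is expected to sit close to compound 3, with an estimated step of a 1.3-fold higher number from compound 3 to compound 4 (0.11 log units; within the scatter) in this assay. Compound 4 is estimated at 90000 nM, with a range from 45000 nM to 180000 nM.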

Compound 4, concentration for 50% growth inhibition: 69700 nM
The estimate for compound 4 lay 1.3-fold (0.11 log units) above the measured number, and the stated range covers the measured number.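

In this assay, methoxy in place of methyl on an aromatic carbon gives no change at the digits printed from compound 3 to compound 4 (within the scatter), and the step on the second core cannot be told apart from the step on the first: the same change on two cores in this assay, a 1.4-fold higher number (0.14 log units; within the scatter) from compound 1 to compound 2 and no change at the digits printed (within the scatter) from compound 3 to compound 4, 1.4-fold (0.14 log units) apart, within the scatter of two such steps. On these two cores, then, 4-methylphenyl and 4-methoxyphenyl are interchangeable within the scatter of this read-out, and the change carries over in the limited sense that neither step is beyond the scatter. This does not show that the change has no effect on other cores, and with neither step beyond the scatter, the pair gives no measurable effect of a size that could be said to transfer.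

The compounds shown leave open whether a different group at this place on the six-membered aromatic ring, such as an amine, a carboxylic acid or a longer alkoxy chain, would move the number beyond the scatter. Also open, from the compounds shown here alone, is how each separate difference between the two cores bears on growth inhibition, as those differences are not taken apart here.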